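Lengthening the alkyl chain on the ring nitrogen

The compounds below may be only part of what the source reports. "The series", "measured", "known", "first", "only" and "open" are said of these compounds alone.

Three compounds share one core and differ only in the group on a nitrogen on an aromatic ring. Compound 1 `O=C(Nc1ncc(C(=O)O)c2nc(-c3ccco3)nn12)NC1CCCCC1` carries a cyclohexylcarbamoyl there; in an assay on CHO cells for displacement of a labelled ligand from adenosine receptor A1 (Homo sapiens) (on this read-out lower numbers stand for stronger inhibition and higher numbers for weaker inhibition), compound 1 gives > 100000 nM, which is a limit of the assay and not a number. Compound 2 `CNc1ncc(C(=O)O)c2nc(-c3ccco3)nn12` carries a methyl; in this assay compound 2 gives > 100000 nM, again a limit. Among the measured compounds shown here, compound 3 `CCNc1ncc(C(=O)O)c2nc(-c3ccco3)nn12` carries an ethyl, and in this assay compound 3 gives 11900 nM, the only number among the three. For compound 1 and compound 2 only a limit of the assay is shown (the limit of > 100000 nM in this assay, at which 2 of the 3 values shown sit). The step of an at least 8.4-fold lower number from compound 2 to compound 3 (0.92 log units; beyond the scatter) and the step of an at least 8.4-fold lower number from compound 1 to compound 3 (0.92 log units; beyond the scatter) both point the same way, while the step that the two limits leave unreadable from compound 1 to compound 2 cannot be read.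

Compound 4 `CCCCC(CC)CNc1ncc(C(=O)O)c2nc(-c3ccco3)nn12` continues the series: 1-ethylpentyl in place of methyl on a saturated chain carbon bound to a nitrogen on an aromatic ring. The only step that bears on it is the one from compound 2 to compound 3, which was at least modest; how far a longer branched chain carries the trend is not shown. Compound 4 is expected to give a lower number, with the step of a 6.0-fold lower number from compound 3 to compound 4 (0.77 log units; beyond the scatter) estimated as modest. The estimate for compound 4 is 2000 nM, between 300 nM and 15000 nM.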

Compound 4, inhibition constant: 1780 nM
Compound 4: the middle estimate sits 1.1-fold (0.05 log units) above what was measured, within the range that was stated.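

In this assay, among the compounds shown here, a 6.7-fold lower number from compound 3 to compound 4 (0.83 log units; beyond the scatter) is the first step at this position read between two real numbers, so the trend towards lower numbers no longer rests on a single value. It also shows that the trend runs past ethyl: the larger, branched 2-ethylhexyl group on the nitrogen on an aromatic ring does not bring the value back to the limit of the assay. Set against the two compounds held at that limit, the change reads as an at least 56-fold lower number from compound 2 to compound 4 (1.74 log units; beyond the scatter) and as an at least 56-fold lower number from compound 1 to compound 4 (1.74 log units; beyond the scatter), and both sizes are bounds and not exact figures: the limit of > 100000 nM in this assay, at which 2 of the 4 values shown sit.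

Compound 4 adds both length and a branch in one change, so the compounds shown cannot tell the two apart, and an unbranched hexyl chain on the same nitrogen would be needed to separate them. Also open, going by these compounds, is where the trend ends, whether with a still longer chain or with a cyclohexyl group bound directly to that nitrogen, and what happens to these values when an ester or an amide replaces the carboxylic acid that all four compounds share.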